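From morpholin-4-yl to (1-phenylethyl)amino on a carbonyl carbon

The compounds below may be only part of what the source reports. "The series", "measured", "known", "first", "only" and "open" are said of these compounds alone.

Measured so far in a physicochemical assay for lipophilicity, read by HPLC; on this read-out lower numbers stand for lower lipophilicity and higher numbers for higher lipophilicity
- compound 1 `Cc1ccsc1C(=CCCN(C)C(CCO)C(=O)N1CCOCC1)c1sccc1C` gives 4.75
- compound 2 `Cc1ccsc1C(=CCCN(C)C(CCN)C(=O)NCc1ccc(F)cc1)c1sccc1C` gives 6.45

Compound 1 holds the lower of the two numbers, and the gap up to compound 2 lies beyond the usual scatter. Compound 3 `Cc1ccsc1C(=CCCN(C)C(CCO)C(=O)NC(C)c1ccccc1)c1sccc1C` has not yet been measured. It departs from compound 1 by one change: (1-phenylethyl)amino in place of morpholin-4-yl on a carbonyl carbon, with (1-phenylethyl)amino in place of morpholin-4-yl on a carbonyl carbon. Among the measured compounds shown here, no measured pair shows this change directly, so the only upper reference is compound 2 at 6.45. A rise beyond the scatter is expected, with an estimated a number 1.15 log units higher from compound 1 to compound 3 (beyond the scatter) in this assay. For compound 3 the estimated value is 5.9, within an expected range from 5.4 to 6.4.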

Compound 3, partition coefficient: 6.1
For compound 3 the middle estimate is 0.20 log units below the measured one; the measured number falls inside the stated range.
By their numbers in this assay, from the lowest: compound 1; then compound 3; then compound 2.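

In this assay, the change from morpholin-4-yl to (1-phenylethyl)amino on a carbonyl carbon gives a number 1.35 log units higher from compound 1 to compound 3 (beyond the scatter), a large step. Among the compounds shown here, this is the first reading at this position with the rest of the structure held constant, and it shows that this group alone can shift the number well beyond the scatter. Nothing measured here explains the step.

For the compounds shown here, the single step does not separate the loss of the morpholine ring from the arrival of the amide hydrogen or the phenyl ring. Piperidin-1-yl or dimethylamino on the same carbonyl carbon would bear on that question, but neither is among the compounds shown.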